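From an ethyl amide to a 2-methylphenyl amide

The compounds below may be only part of what the source reports. "The series", "measured", "known", "first", "only" and "open" are said of these compounds alone.

Measured compounds:
compound 1, `CNC(=O)c1nc(-c2cc(OC)c(OC)c(OC)c2)n(-c2ccc(OC)cc2)n1`: 74%
compound 2, `CCNC(=O)c1nc(-c2cc(OC)c(OC)c(OC)c2)n(-c2ccc(OC)cc2)n1`: 68%
compound 3, `COc1ccc(-n2nc(C(=O)Nc3ccccc3OC)nc2-c2cc(OC)c(OC)c(OC)c2)cc1`: 57%

In a functional assay on the whole organism for inhibition, with Rattus norvegicus as the target, read by paw edema, with stated times of 30 min and 2 h, at a dose of 0.28 mmol/kg by the oral route (a higher number here means more inhibition at the dose given (going by the name of the read-out), a lower number less inhibition), compound 2 stands second of the three measured numbers. Its nearest neighbour is compound 1, and the step of a number 6 percentage points lower from compound 1 to compound 2 (within the scatter) is within the scatter, so no order between the two can be claimed. For the measured compounds named here, the only step beyond the scatter from compound 2 leads to compound 3: a number 11 percentage points lower from compound 2 to compound 3 (beyond the scatter). Compound 1 shows the same direction toward compound 3, with a number 17 percentage points lower from compound 1 to compound 3 (beyond the scatter).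

Compound 4, `COc1ccc(-n2nc(C(=O)Nc3ccccc3C)nc2-c2cc(OC)c(OC)c(OC)c2)cc1`, has not been measured. It differs from compound 2 in one place: 2-methylphenyl in place of ethyl on an amide-type nitrogen. Going by the values given here, the change that bears on it is the one from compound 2 to compound 3, where 2-methoxyphenyl replaced ethyl on the same amide-type nitrogen and the number fell modestly. Both 1>3 and 2>3 show a modest loss when an aryl group enters in place of a small alkyl at this nitrogen. A step of similar size and direction is therefore expected, a number 10 percentage points lower from compound 2 to compound 4 (within the scatter). Compound 4 is estimated to give 58%, within the range 45% to 70%.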

Compound 4, a percentage reported as inhibition, in the whole organism at one dose (the size of the read-out at that dose, not a potency): 30%
Compound 4: middle estimate off by 28 percentage points, on the high side; the measured number lies below the stated range.
By their numbers in this assay, from the lowest: compound 4; then compound 3; then compounds 2 and 1 (each within the scatter of the next).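

In this assay, putting an aryl group on the amide-type nitrogen does not always cost only a modest amount: the change gives a number 38 percentage points lower from compound 2 to compound 4 (beyond the scatter) and a number 44 percentage points lower from compound 1 to compound 4 (beyond the scatter). The earlier compounds shown here could not show that the aryl group's own substituent matters here, but with methyl in place of methoxy on an aromatic carbon the result is a number 27 percentage points lower from compound 3 to compound 4 (beyond the scatter). The modest loss seen with compound 3 therefore does not carry over to compound 4, and the 2-methoxyphenyl amide stands out as the better retained of the two aryl amides.

The compounds shown leave open how a plain phenyl or a benzyl group would read on this nitrogen. Nothing reported here accounts for the gap between the methyl and methoxy compounds.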